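Stilbene hydroxy-to-amino swap: what to expect next

The source may hold more compounds than are shown below. What is called first, only, known or untested is meant among the compounds shown, and "the series" means these compounds.

Measured so far:
Compound 1, `Oc1ccc(/C=C/c2ccccc2O)cc1` — 17.5 ug/mL
Compound 2, `Nc1ccc(/C=C/c2ccccc2O)cc1` — 21.4 ug/mL
Compound 3, `COc1cccc(/C=C/c2cccc(O)c2)c1` — 19 ug/mL

In an ADME assay on HEK293 cells (Homo sapiens) for inhibition, read by MTT assay, with a stated time of 2 days (on this read-out higher numbers stand for weaker inhibition and lower numbers for stronger inhibition), compound 1 gives 17.5 ug/mL. Compound 2, in this assay, gives 21.4 ug/mL, and the change between them is amino in place of hydroxy on an aromatic carbon, a step of a 1.2-fold higher number from compound 1 to compound 2 (0.09 log units; within the scatter). Compound 3 gives 19 ug/mL in this assay; the difference between its core and the core of compound 1 is not broken down here.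

Compound 4, `COc1cccc(/C=C/c2cccc(N)c2)c1`, has not been measured. It differs from compound 3 by amino in place of hydroxy on an aromatic carbon. This is the same kind of change as that from compound 1 to compound 2, but the place differs: there the group stood para to a group of 9 heavy atoms, here it sits meta to a large group.

Resting on the step of a 1.2-fold higher number from compound 1 to compound 2 (0.09 log units; within the scatter), compound 4 is expected to give about 22 ug/mL in this assay, a step of a 1.2-fold higher number from compound 3 to compound 4 (0.06 log units; within the scatter), within the scatter.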

Compound 4, half-maximal inhibitory concentration: 16 ug/mL
The estimate for compound 4 lay 1.4-fold (0.14 log units) above the measured number, and the stated range covers the measured number.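

Putting amino in place of hydroxy on the core of compound 3 gives, in this assay, a 1.2-fold lower number from compound 3 to compound 4 (0.07 log units; within the scatter). Set beside the same swap on the core of compound 1, the two steps cannot be told apart: the same change on two cores in this assay, a 1.2-fold higher number (0.09 log units; within the scatter) from compound 1 to compound 2 and a 1.2-fold lower number (0.07 log units; within the scatter) from compound 3 to compound 4, 1.5-fold (0.16 log units) apart, within the scatter of two such steps. On these two cores the swap leaves the number within the usual scatter, but two pairs cannot show that this holds on other cores, and steps this small give no direction for the swap.

The compounds shown leave open whether a carboxylic acid or a nitrile in place of the hydroxy would give a step beyond the scatter. They also leave open whether the swap behaves the same way in any other assay.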